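From nitro to methoxy on an aromatic ring

The compounds below may be only part of what the source reports. "The series", "measured", "known", "first", "only" and "open" are said of these compounds alone.

compound 1 `COc1ccc2cc(C(C)c3nnc4n3N=C(c3ccc([N+](=O)[O-])cc3)CS4)ccc2c1`: 18800 nM
compound 2 `CC(c1ccc(-c2ccccc2)c(F)c1)c1nnc2n1N=C(c1ccc(OC(F)(F)F)cc1)CS2`: 4800 nM
compound 3 `CC(C)Cc1ccc(C(C)c2n[nH]c(=S)n2N)cc1`: 16100 nM

These three numbers come from a functional assay on MCF7 cells (Homo sapiens) for inhibition, read by sulforhodamine B assay, with a stated time of 72 h; on this read-out higher numbers stand for weaker inhibition and lower numbers for stronger inhibition. Compound 1 gives 18800 nM, and compound 3 at 16100 nM lies within the usual scatter of it. Compound 2 at 4800 nM has a lower number than compound 1, and that gap lies beyond the scatter.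

The next compound to be tested is compound 4 `COc1ccc(C2=Nn3c(nnc3C(C)c3ccc4cc(OC)ccc4c3)SC2)cc1`, which keeps the core of compound 1 and changes one group: methoxy in place of nitro on an aromatic carbon. This puts methoxy in place of nitro on an aromatic carbon, para to a large group. For the measured compounds named here, no measured pair shows this change on its own, so the data give no direct size for it. A small move toward a lower number in this assay is expected, but nothing beyond the scatter. The expected step is a 1.6-fold lower number from compound 1 to compound 4 (0.19 log units; within the scatter). For compound 4 the estimated value is 12000 nM, with an expected range of 4000 nM to 35000 nM.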

Compound 4, half-maximal inhibitory concentration: 6600 nM
Compound 4: the middle estimate sits 1.8-fold (0.26 log units) above what was measured; low and high end bracket the measured number.
By their numbers in this assay, from the lowest: compounds 2 and 4 (each within the scatter of the next); then compounds 3 and 1 (each within the scatter of the next).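

In this assay, replacing the 4-nitrophenyl group with 4-methoxyphenyl gives a 2.8-fold lower number from compound 1 to compound 4 (0.45 log units; beyond the scatter). For the compounds shown here, this is the first pair in the set that differs in one place only, and it shows that the group on this aromatic carbon, para to a large group, can shift the read-out by more than the usual scatter. Nothing measured here explains why the number falls with this change.

Going by these compounds, it remains open whether an amine, a nitrile or a fluorine atom at the same place would give a lower or a higher number than methoxy. On these data alone, this is also a single pair on a single core, and whether the change from nitro to methoxy gives a similar step on another core remains open.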